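This account rests on a few compounds, and the source may have more. Where it says the series, first, only, none or still open, it means among the compounds named here.

Measured so far in a physicochemical assay for solubility, read by LC-MS, in phosphate buffer, with a stated time of 24 h, at pH 7.4; on this read-out lower numbers stand for lower solubility and higher numbers for higher solubility:
- compound 1, `Cc1nc(CO)ccc1-c1cnc(NCc2c(F)ccc3c2CCO3)c2cn[nH]c(=O)c12`: 3000 nM
- compound 2, `Cc1ncccc1-c1cnc(NCc2c(F)ccc3c2CCO3)c2ncc(=O)[nH]c12`: 29000 nM

Of the two numbers, compound 1 has the lower one. Going by the values given here, the nearest, compound 2, gives 29000 nM against 3000 nM for compound 1, a gap beyond the usual scatter; the two share the aryl-amine side but differ in more than one place, so this pair carries no single-change step.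

Compound 3, `CNC(=O)c1ncc(-c2cnc(NCc3c(F)ccc4c3CCO4)c3cn[nH]c(=O)c23)n1C`, is not yet measured. It differs from compound 1 in one place: 1-methyl-2-(methylcarbamoyl)-1H-imidazol-5-yl in place of 6-(hydroxymethyl)-2-methylpyridin-3-yl on an aromatic carbon.

Among the compounds with values here, no step between measured compounds bears on this change, so the expectation rests on the change alone. The group that enters brings one more hydrogen-bond acceptor and keeps one hydrogen-bond donor, while the hydroxymethyl group leaves; a modest rise in this assay is expected, with a real chance of none beyond the scatter. The step expected is a 2.0-fold higher number from compound 1 to compound 3 (0.30 log units; within the scatter). For compound 3 the estimate in this assay is 6000 nM, with a range from 1500 nM to 25000 nM.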

Compound 3, solubility: 5000 nM
The estimate for compound 3 lay 1.2-fold (0.08 log units) above the measured number; low and high end bracket the measured number.
By their numbers in this assay, from the lowest: compounds 1 and 3 (each within the scatter of the next); then compound 2.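

In this assay, going by these compounds alone, the first single-change step at this position gives a 1.7-fold higher number from compound 1 to compound 3 (0.22 log units; within the scatter) and so does not separate the two groups: 1-methyl-2-(methylcarbamoyl)-1H-imidazol-5-yl and 6-(hydroxymethyl)-2-methylpyridin-3-yl cannot be told apart on this read-out. The exchange is not a small one, since a six-membered aromatic ring with 1 hetero atom gives way to a five-membered aromatic ring with 2 hetero atoms, and 2 hydrogen-bond acceptors give way to 3, while each group carries 1 hydrogen-bond donor; even so, this one pair shows no change in the number beyond the scatter on this aromatic carbon. No measurement is available that would explain this outcome.

Because the ring and its substituents change together in this step, the separate contributions of the hydroxymethyl group, the methylcarbamoyl group and the ring itself remain unresolved. Also open, as far as these compounds go, is whether a group of another kind at this position, such as a carboxylic acid or an aminomethyl group, would move the number in this assay beyond the scatter.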